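Fluoro for hydrogen on the sugar ring of compound 2

This account rests on a few compounds, and the source may have more. Where it says the series, first, only, none or still open, it means among the compounds named here.

Compound 2 `O=c1nc(NO)ccn1[C@@H]1CC[C@H](CO)O1` stands highest of the two numbers in an ADME assay on HepG2 cells (Homo sapiens) for cytotoxicity, read by MTT assay, with a stated time of 3 days (a higher number here means that more compound is tolerated, a lower number that less compound is tolerated), where compound 2 gives 2250000 nM. Its nearest neighbour is compound 1 `[N-]=[N+]=N[C@@H]1C[C@@H](n2ccc(NO)nc2=O)O[C@H]1CO`, which in this assay gives 1160000 nM; the step of a 1.9-fold higher number from compound 1 to compound 2 (0.29 log units; within the scatter) lies within the scatter. Compound 3 `O=c1nc(NO)ccn1[C@@H]1CC(F)[C@H](CO)O1` differs from compound 2 by fluoro in place of hydrogen on a saturated ring carbon. For the measured compounds named here, only that one step bears on this change, and it showed nothing beyond the scatter, so no step beyond the scatter is expected in this assay for compound 3, whose value is estimated at 2000000 nM within 700000 nM to 5000000 nM, an expected step of a 1.1-fold lower number from compound 2 to compound 3 (0.05 log units; within the scatter).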

Compound 3, half-maximal cytotoxic concentration: 820000 nM
For compound 3 the middle estimate is 2.4-fold (0.39 log units) above the measured one, within the range that was stated.
By their numbers in this assay, from the lowest: compounds 3, 1 and 2 (each within the scatter of the next, the first and the last beyond it).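

In this assay this saturated ring carbon proves responsive to a small change, with a 2.7-fold lower number from compound 2 to compound 3 (0.44 log units; beyond the scatter) for fluoro in place of hydrogen. The earlier pair, with hydrogen in place of azido at this carbon, gave only a 1.9-fold higher number from compound 1 to compound 2 (0.29 log units; within the scatter) and so showed nothing beyond the scatter. No measurement at hand accounts for the fluoro step. From the compounds shown here alone, whether a hydroxyl, a chloro or an amine on this carbon would shift the number as fluoro does stays open. So does the effect of fluoro's orientation on the ring, which the compounds shown do not separate.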